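The compounds below may be only part of what the source reports. "The series", "measured", "known", "first", "only" and "open" are said of these compounds alone.

Among the measured compounds shown here, compound 1, with the structure `CN(C)c1cc2[nH]c(C3CCCCC3)nc2cc1NC(=O)c1ccccc1`, is one of three compounds tested so far in an ADME assay on Vero cells (Chlorocebus sabaeus) for cytotoxicity, read by resazurin assay, with a stated time of 3 days; a lower number here means a stronger inhibitor, a higher number a weaker inhibitor. In this assay compound 1 gives only a limit, > 100 ug/mL, and not a measured number. Compound 2, `CCN(CC)c1cc2[nH]c(C3CCCCC3)nc2cc1NC(=O)OCC(F)(F)F`, likewise gives a limit in this assay, > 100 ug/mL. Compound 3, `CCOCCOC(=O)Nc1cc2nc(C3CCCCC3)[nH]c2cc1N1CCCC1`, gives in this assay the limit > 100 ug/mL. So all that is known of compound 1 is that it sits at the limit of > 100 ug/mL in this assay, at which 3 of the 3 values shown sit, together with the other two, and no ranking among the three can be drawn from this.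

The next compound, compound 4, has the structure `CCCOCC(=O)Nc1cc2nc(C3CCCCC3)[nH]c2cc1N(C)C`. It differs from compound 1 in one place: propoxymethyl in place of phenyl on a carbonyl carbon. For the measured compounds named here, no pair of measured compounds shows this change, so its effect cannot be read from the numbers at hand. With every value in this assay sitting at the same limit, the expected step from compound 1 to compound 4 is a step that the limit leaves unreadable from compound 1 to compound 4, which is no step beyond the scatter. Compound 4 is therefore estimated in this assay at 150 ug/mL, within a range from 60 ug/mL to 400 ug/mL, and most likely it will again be reported only as a limit.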

Compound 4, half-maximal inhibitory concentration: < 50 ug/mL
Compound 4: a limit, no number; the forecaster's own chance of this, stated with the estimate: 80%; at least 3.0-fold (0.47 log units) between middle value and limit.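

In this assay compound 4 gives < 50 ug/mL, which is a limit and not a number. Of the four compounds shown, it is the only one not at the upper limit, so the group on this carbonyl carbon is not neutral for this read-out: the change gives an at least 2.0-fold lower number from compound 1 to compound 4 (0.30 log units; that floor lies within the scatter). Both ends of this step are limits, so only its direction and floor can be read, not its true size: the limit of < 50 ug/mL in this assay, at which 1 of the 4 values shown sits.

The compounds shown do not separate the loss of the phenyl ring from the arrival of the ether oxygen, and a plain butyl chain on the same carbonyl carbon would pull these two apart. From the compounds shown here alone, it also stays open whether a shorter ether chain, or an amine at the end of the chain, would give the same result.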